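Returning to a bridged bicyclic amine on the quinoline core

The source may report more compounds than this note shows. Statements on the series, on what has been measured and on what is new or still open speak of the compounds shown alone.

Compound 2 `O=C(CCc1ccc(C(F)(F)F)cc1)Nc1ccc2nc(N3CCC3)ccc2c1` carries an azetidin-1-yl group on the shared core. In a functional assay on HEK293 cells for activation of melanin-concentrating hormone receptor 1 (Rattus norvegicus), read by inositol phosphate accumulation (on this read-out higher numbers stand for an effect only at larger amounts of compound and lower numbers for an effect already at smaller amounts), compound 2 gives 56 nM, the lowest of the two single numbers recorded; the nearest is compound 1 `O=C(CCc1ccc(C(F)(F)F)cc1)Nc1ccc2nc(N3CC4CC3CN4)ccc2c1`, which in this assay gives 490 nM. Compound 3 `O=C(CCc1ccc(C(F)(F)F)cc1)Nc1ccc2nc(N3CCCC3)ccc2c1`, with a five-membered ring in the same place, gives 320 nM; 320 nM (2 entries) in this assay across two entries.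

Compound 4 `O=C(CCc1ccc(C(F)(F)F)cc1)Nc1ccc2nc(N3CC4CC3CO4)ccc2c1` differs from compound 2 in one place: a group of 7 heavy atoms (5 carbon, 1 nitrogen, 1 oxygen; 2 five-membered non-aromatic rings with 1 hetero atom each) in place of a group of 4 heavy atoms (3 carbon, 1 nitrogen; one four-membered non-aromatic ring with 1 hetero atom), on an aromatic carbon. For the measured compounds named here, the entering group closely resembles the one on compound 1, except that one ring nitrogen is now an oxygen.

The step that bears most directly on this change is an 8.8-fold lower number from compound 1 to compound 2 (0.94 log units; beyond the scatter), which runs in the opposite direction to the present change. Swapping the four-membered ring of compound 2 back for a two-ring group of the same shape is therefore expected to move the number upward by an amount of similar size, and the value of compound 3 points the same way, since a larger ring there also sits well above compound 2. Whether the oxygen instead of the second nitrogen softens this is not shown by any measured pair.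

Compound 4 is expected to give about 350 nM in this assay, within 120 nM to 1000 nM, an estimated step of a 6.3-fold higher number from compound 2 to compound 4 (0.80 log units; beyond the scatter).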

Compound 4, half-maximal effective concentration: 70 nM
Compound 4: the middle estimate sits 5.0-fold (0.70 log units) above what was measured; the measured number lies below the stated range.
By their numbers in this assay, from the lowest: compounds 2 and 4 (each within the scatter of the next); then compound 1.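

Compound 4 shows that a large two-ring group can sit on this aromatic carbon without a clear cost: in this assay the exchange of azetidin-1-yl for this group gives a 1.3-fold higher number from compound 2 to compound 4 (0.10 log units; within the scatter), so compound 2 and compound 4 stand level, and compound 4 goes against the earlier impression that larger groups here bring higher numbers. The exchange of one ring nitrogen for an oxygen within the same two-ring frame gives a 7.0-fold lower number from compound 1 to compound 4 (0.85 log units; beyond the scatter), which means that group size and ring count alone do not account for the high number of compound 1, and that the identity of this single ring atom matters at this position. Nothing measured here explains why this one atom makes such a difference.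

The compounds shown leave open whether the high number of compound 1 is tied to the hydrogen on its second ring nitrogen, which a methyl or acetyl group on that nitrogen could test. They also leave open how a six-membered group such as piperidin-1-yl or morpholin-4-yl, or the same two-ring frame with sulfur in place of the oxygen, would fare at this position.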